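The source may hold more compounds than are shown below. What is called first, only, known or untested is meant among the compounds shown, and "the series" means these compounds.

Measured in a functional assay on MDA-MB-231 cells (Homo sapiens) for inhibition, read by MTT assay, with a stated time of 48 h; on this read-out lower numbers stand for stronger inhibition of growth and higher numbers for weaker inhibition of growth:
- compound 1 `CCc1cccc(Nc2ncnc3ccc(NC(=S)NCc4ccccc4)cc23)c1`: 10500 nM
- compound 2 `NS(=O)(=O)c1ccc(NC(=S)Nc2ccc3ncnc(Nc4cccc(Br)c4)c3c2)cc1`: > 30000 nM

Compound 2 stands at a limit of this assay, not at a number: > 30000 nM.

Compound 3 `FC(F)(F)c1ccc(NC(=S)Nc2ccc3ncnc(Nc4cccc(Br)c4)c3c2)cc1` carries trifluoromethyl in place of sulfamoyl on an aromatic carbon, para to a large group (trifluoromethyl in place of sulfamoyl on an aromatic carbon). Among the measured compounds shown here, no measured step covers this change. For the measured compounds named here, the only numerical anchor is compound 1 at 10500 nM. A move towards stronger inhibition of growth is expected, with an estimated at least 2.7-fold lower number from compound 2 to compound 3 (0.43 log units; beyond the scatter). For compound 3 the estimated value is 11000 nM, with an expected range of 3500 nM to 30000 nM.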

Compound 3, concentration for 50% growth inhibition: 12200 nM
Compound 3: the middle estimate sits 1.1-fold (0.04 log units) below what was measured; low and high end bracket the measured number.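

Trifluoromethyl in place of sulfamoyl on this aromatic carbon, para to a large group, gives an at least 2.4-fold lower number from compound 2 to compound 3 (0.39 log units; beyond the scatter) in this assay. Among the compounds shown here, this is the first sign that the group at this place affects growth inhibition, and compound 3 gives a number where compound 2 gave none. Compound 2 stands at a limit, so the step fixes only a minimum size: the limit of > 30000 nM in this assay, at which 1 of the 3 values shown sits.

On these data alone, whether a carboxylic acid, an amine or a nitrile at this place would read like sulfamoyl or like trifluoromethyl stays open. One pair also cannot show which difference between the two groups carries the step.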